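Anilino variation on the 4-methylphenyl core

The source may hold more compounds than are shown below. What is called first, only, known or untested is meant among the compounds shown, and "the series" means these compounds.

In a functional assay on ECa-109 cells (Homo sapiens) for inhibition, read by MTT assay, with a stated time of 72 h (a lower number here means a stronger inhibitor, a higher number a weaker inhibitor), two compounds give numbers and one gives only a limit. Compound 2 `Cc1ccc(-c2nc(SCc3cn(CC(=O)NC(=O)Nc4ccccn4)nn3)nc(Nc3ccc(C(C)C)cc3)c2C#N)cc1` gives 7450 nM. Compound 3 `COc1ccccc1Nc1nc(SCc2cn(CC(=O)NC(=O)Nc3ccccn3)nn2)nc(-c2ccc(C)cc2)c1C#N` gives 7850 nM, the higher of the two numbers, though the step of a 1.1-fold higher number from compound 2 to compound 3 (0.02 log units; within the scatter) lies within the scatter. Compound 1 `COc1cc(-c2nc(SCc3cn(CC(=O)NC(=O)Nc4ccccn4)nn3)nc(Nc3cccc(Cl)c3)c2C#N)cc(OC)c1OC` reports only the assay limit > 64000 nM and no number; compound 1 carries the same 3-chlorophenyl on the ring nitrogen as compound 4 but a different aryl on the shared core, so its limit cannot be read as a step toward compound 4.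

Compound 4 `Cc1ccc(-c2nc(SCc3cn(CC(=O)NC(=O)Nc4ccccn4)nn3)nc(Nc3cccc(Cl)c3)c2C#N)cc1` differs from compound 3 by 3-chlorophenyl in place of 2-methoxyphenyl on a nitrogen on an aromatic ring. Among the compounds with values here, the one measured step that bears on this position, from compound 2 to compound 3, was within the scatter, so the anilino aryl appears to move this assay little among the compounds with a 4-methylphenyl on the core. The expected step of a 1.3-fold higher number from compound 3 to compound 4 (0.11 log units; within the scatter) is therefore small, with some chance of a weaker number. Compound 4 is estimated at 10000 nM, in the range 4000 nM to 40000 nM.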

Compound 4, half-maximal inhibitory concentration: 25600 nM
Compound 4: the middle estimate sits 2.6-fold (0.41 log units) below what was measured, within the range that was stated.
By their numbers in this assay, from the lowest: compounds 2 and 3 (each within the scatter of the next); then compound 4. At a limit, above all of these: compound 1.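

In this assay the anilino aryl on the 4-methylphenyl core does register: a 3.3-fold higher number from compound 3 to compound 4 (0.51 log units; beyond the scatter) and a 3.4-fold higher number from compound 2 to compound 4 (0.54 log units; beyond the scatter) both lie beyond the scatter, whereas a 1.1-fold higher number from compound 2 to compound 3 (0.02 log units; within the scatter) does not. The 3-chlorophenyl therefore stands apart from the 2-methoxyphenyl and the 4-isopropylphenyl, which stay within the scatter of each other. With the 3-chlorophenyl held, 4-methylphenyl in place of 3,4,5-trimethoxyphenyl on the aromatic carbon gives an at least 2.5-fold lower number from compound 1 to compound 4 (0.39 log units; beyond the scatter) as a bound only, and compound 1 gives a limit and not a number: the limit of > 64000 nM in this assay, at which 1 of the 4 values shown sits.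

Open, going by these compounds, is whether the step on the nitrogen goes with chlorine as such: a 3-methoxyphenyl or a 4-chlorophenyl there would test that. On these data alone, the true size of the step on the aromatic carbon also stays open, with only a limit on one side of it.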